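This account rests on a few compounds, and the source may have more. Where it says the series, first, only, none or still open, it means among the compounds named here.

Measured so far in a functional assay on FM3A cells (Mus musculus) for antiproliferative activity; a higher number here means a weaker inhibitor, a lower number a stronger inhibitor:
compound 1, `CCOc1ccc(-c2cc(N)c(C(=O)c3cc(OC)c(OC)c(OC)c3)s2)cc1` — 510 nM
compound 2, `COc1ccc(-c2cc(N)c(C(=O)c3cc(OC)c(OC)c(OC)c3)s2)cc1OC` — 72 nM
compound 3, `COc1cc(C(=O)c2sc(-c3ccccc3)cc2N)cc(OC)c1OC` — 13 nM

Compound 3 holds the lowest number of the three and is therefore the strongest inhibitor in this assay; its nearest neighbour is compound 2, and the gap to compound 1 is the widest in the set.

Compound 4, `COc1cccc(-c2cc(N)c(C(=O)c3cc(OC)c(OC)c(OC)c3)s2)c1`, is not yet measured. It differs from compound 3 by methoxy in place of hydrogen on an aromatic carbon; cut one bond further out, the change reads phenyl to 3-methoxyphenyl.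

Among the compounds with values here, two measured steps bear on this. Removing both methoxy groups from the 3,4-dimethoxyphenyl gave a 5.5-fold lower number from compound 2 to compound 3 (0.74 log units; beyond the scatter), and removing the ethoxy from the 4-ethoxyphenyl gave a 39-fold lower number from compound 1 to compound 3 (1.59 log units; beyond the scatter). Both substituted phenyls thus sit at higher numbers than the bare phenyl. A single methoxy is a smaller addition than either, so a modest rise is expected, a 2.3-fold higher number from compound 3 to compound 4 (0.36 log units; beyond the scatter), smaller than the step from compound 2 to compound 3.

Compound 4 is estimated at 30 nM, with a likely range of 10 nM to 100 nM.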

Compound 4, half-maximal inhibitory concentration: 36 nM
Estimate against measurement, compound 4: 1.2-fold (0.08 log units) below, within the range that was stated.
By their numbers in this assay, from the lowest: compound 3; then compounds 4 and 2 (each within the scatter of the next); then compound 1.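

In this assay, one methoxy on the phenyl, meta to a large group, is already enough to give a step beyond the scatter, a 2.8-fold higher number from compound 3 to compound 4 (0.44 log units; beyond the scatter); the 3,4-dimethoxyphenyl cannot be told apart from this 3-methoxyphenyl, with a 2.0-fold lower number from compound 2 to compound 4 (0.30 log units; within the scatter). The 4-ethoxyphenyl stands well apart from the 3-methoxyphenyl, with a 14-fold lower number from compound 1 to compound 4 (1.15 log units; beyond the scatter), although that step changes both the group and its place on the ring, so neither change can be read alone. No measured evidence on the cause of these steps is available.

Open, as far as these compounds go, is whether a hydroxy, a fluorine or an amine in the same place would stay as close to compound 3. Also open, from the compounds shown here alone, is whether a longer chain such as ethoxy there would move the number as far as the 4-ethoxyphenyl does.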